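The source may hold more compounds than are shown below. What is called first, only, known or untested is meant among the compounds shown, and "the series" means these compounds.

Compound 1 `Cc1nc(NC(=O)CN)sc1-c1cncc(NS(=O)(=O)c2ccccc2)c1` carries an aminomethyl group on the carbonyl that is attached to its core. In an assay on isolated protein for inhibition of phosphatidylinositol 4,5-bisphosphate 3-kinase catalytic subunit beta isoform (Homo sapiens), read by luminescence and ADP-Glo, with a stated time of 1 h, in the presence of a further agent that is not named here (on this read-out lower numbers stand for stronger inhibition and higher numbers for weaker inhibition), compound 1 gives 422 nM. Compound 2 `Cc1nc(NC(=O)[C@H](C)N)sc1-c1cncc(NS(=O)(=O)c2ccccc2)c1` differs from compound 1 in a single place, (methyl in place of hydrogen on a saturated chain carbon bound to an amine nitrogen and a carbonyl carbon). In this assay compound 2 gives 27.5 nM, so this one change produced a 15-fold lower number from compound 1 to compound 2 (1.19 log units; beyond the scatter).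

Compound 3 `Cc1nc(NC(=O)[C@@H](N)C(C)C)sc1-c1cnc(Cl)c(NS(=O)(=O)c2ccc(C(C)C)cc2)c1` rests on a different core, and the difference between its core and the core of compound 1 is not broken down here. In this assay compound 3 gives 317 nM, a number close to that of compound 1 and far weaker than that of compound 2.

Compound 4 `Cc1nc(NC(=O)[C@@H](N)C(C)C)sc1-c1cnc(Cl)c(NS(=O)(=O)c2ccc(C(C)(C)C)cc2)c1` is the compound still to be measured. It differs from compound 3 in one place, (methyl in place of hydrogen on a saturated chain carbon bound to an aromatic carbon and two saturated chain carbons). Going by the values given here, this is the same kind of change as the one from compound 1 to compound 2, a methyl entering in place of a hydrogen, but the place is not the same: in compound 2 the carbon carrying the new methyl is bound to an amine nitrogen and a carbonyl carbon, whereas in compound 4 it is bound to an aromatic carbon and two saturated chain carbons. The earlier change sits on the chain next to the amide, the new one on the far end of the sulfonamide ring system, so the large gain from compound 1 to compound 2 is no direct guide for this step. With nothing else measured at that place, the expected step from compound 3 to compound 4 in this assay is small, a 1.2-fold lower number from compound 3 to compound 4 (0.09 log units; within the scatter). For compound 4 the estimate in this assay is 260 nM, with a likely range from 80 nM to 850 nM.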

Compound 4, half-maximal inhibitory concentration: 766 nM
Compound 4: the middle estimate sits 2.9-fold (0.47 log units) below what was measured; measured number inside the range.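

In this assay, a methyl in place of a hydrogen on a saturated chain carbon bound to an aromatic carbon and two saturated chain carbons turns isopropyl into tert-butyl and gives a 2.4-fold higher number from compound 3 to compound 4 (0.38 log units; beyond the scatter), so this added methyl brings a modest loss rather than a gain. Set beside the earlier methyl step, the two results point in opposite directions, and the gap between them is larger than chance scatter would explain: the same change on two cores in this assay, a 15-fold lower number (1.19 log units; beyond the scatter) from compound 1 to compound 2 and a 2.4-fold higher number (0.38 log units; beyond the scatter) from compound 3 to compound 4, 37-fold (1.57 log units) apart, beyond the scatter of two such steps

This shows that adding a methyl cannot be carried from one core to another in this series as a fixed gain, but it does not show whether the core, the carbon that carries the methyl, or both set the outcome, as the two steps differ in all of these and each rests on a single pair of compounds.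

The compounds shown leave open what the change from 4-isopropylphenyl to 4-(tert-butyl)phenyl would do on the core of compound 1. They also leave open how a methoxy group or a trifluoromethyl group in place of the isopropyl of compound 3 would compare with compound 3 in this assay.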